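Trimming a Dihydroxypropyl Amide Tail: What to Expect

This account rests on a few compounds, and the source may have more. Where it says the series, first, only, none or still open, it means among the compounds named here.

Three compounds share one core and differ only in a side chain on a saturated chain carbon bound to a saturated ring carbon. Compound 1 `Cn1ncc(Cl)c1-c1cc(C(=O)N[C@@H]2CN[C@H](CCN3CCC(O)CC3)C[C@H]2c2ccc(Cl)c(Cl)c2)oc1Cl` carries a (4-hydroxypiperidin-1-yl)methyl group there; in an assay for inhibition of RAC-alpha serine/threonine-protein kinase (Homo sapiens), read by HTRF, with a stated time of 1 h (a higher number here means a weaker inhibitor, a lower number a stronger inhibitor), compound 1 gives 5.99 nM. Compound 2 `Cn1ncc(Cl)c1-c1cc(C(=O)N[C@@H]2CN[C@H](CC(N)=O)C[C@H]2c2ccc(Cl)c(Cl)c2)oc1Cl` carries a carbamoyl group instead, and in this assay compound 2 gives 3.24 nM. Compound 3 `Cn1ncc(Cl)c1-c1cc(C(=O)N[C@@H]2CN[C@H](CC(=O)NCC(O)CO)C[C@H]2c2ccc(Cl)c(Cl)c2)oc1Cl` extends that amide with a 2,3-dihydroxypropyl group on the amide nitrogen, and in this assay compound 3 gives 3.13 nM, the lowest of the three numbers, though its gaps to the other two stay within the scatter: a 1.9-fold lower number from compound 1 to compound 3 (0.28 log units; within the scatter) and a 1.0-fold lower number from compound 2 to compound 3 (0.02 log units; within the scatter).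

Compound 4 `Cn1ncc(Cl)c1-c1cc(C(=O)N[C@@H]2CN[C@H](CC(=O)NCCO)C[C@H]2c2ccc(Cl)c(Cl)c2)oc1Cl` takes one further step: hydrogen in place of hydroxymethyl on a saturated chain carbon bound to an oxygen on a saturated carbon and a saturated chain carbon. The amide tail thus shrinks from 2,3-dihydroxypropyl to 2-hydroxyethyl, so compound 4 carries a shorter tail than compound 3 and a longer one than compound 2. The step that bears most directly on this is a 1.0-fold lower number from compound 2 to compound 3 (0.02 log units; within the scatter), where adding the whole 2,3-dihydroxypropyl group moved the number by no more than the scatter; a 1.8-fold lower number from compound 1 to compound 2 (0.27 log units; within the scatter) likewise shows a larger exchange at the same place staying within the scatter. Removing one hydroxymethyl is therefore expected to produce no change beyond the scatter, and the estimated step is a 1.0-fold higher number from compound 3 to compound 4 (0.01 log units; within the scatter). Compound 4 is expected to give 3.2 nM in this assay, with a range from 1.6 nM to 6.5 nM.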

Compound 4, half-maximal inhibitory concentration: 1.41 nM
For compound 4 the middle estimate is 2.3-fold (0.36 log units) above the measured one; measured number below the stated range.
By their numbers in this assay, from the lowest: compound 4; then compounds 3, 2 and 1 (each within the scatter of the next).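

Until now, no exchange at this place had moved the number beyond the scatter, so the side chain could have seemed to tolerate any change without effect. In this assay, removing a single hydroxymethyl gives a 2.2-fold lower number from compound 3 to compound 4 (0.35 log units; beyond the scatter) and shows that a small edit to the tail can register. The choice of tail on the amide nitrogen also matters: 2-hydroxyethyl in place of hydrogen gives a 2.3-fold lower number from compound 2 to compound 4 (0.36 log units; beyond the scatter) while 2,3-dihydroxypropyl in that same place gave only a 1.0-fold lower number from compound 2 to compound 3 (0.02 log units; within the scatter) and, measured against the (4-hydroxypiperidin-1-yl)methyl group, the (2-hydroxyethyl)carbamoyl group gives a 4.2-fold lower number from compound 1 to compound 4 (0.63 log units; beyond the scatter) so compound 4 stands apart from all three others, though each of its steps is modest.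

No measurement shown here explains why the shorter tail gives the lower number. From the compounds shown here alone, it also remains open whether the hydroxyl of the 2-hydroxyethyl tail is needed, and whether a plain ethyl, a longer 3-hydroxypropyl chain or a 2-aminoethyl group on the amide nitrogen would match compound 4.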